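A few compounds are considered here, and "the series" means these few. Any claim that something is new, unique, unknown or untested is made for them only; others in the source may bear on it.

Compound 3 (`COc1ccc(-c2nc(CNC(=O)CSC)sc2-c2ccc(OC)cc2)cc1`) is known in a functional assay with Oryctolagus cuniculus as the target (on this read-out lower numbers stand for stronger inhibition and higher numbers for weaker inhibition), only as a limit, < 100 nM. No exact number is available for it. Compound 1 (`CC/N=C(/N)Nc1nc(-c2ccc(OC)cc2)c(-c2ccc(OC)cc2)s1`) also carries only a limit, > 100 nM. Compound 2 (`COc1ccc(-c2nc(/N=C(\N)N3CCOCC3)sc2-c2ccc(OC)cc2)cc1`) likewise carries only a limit, < 1000 nM.

The next compound, compound 4 (`CNC(=O)NCc1nc(-c2ccc(OC)cc2)c(-c2ccc(OC)cc2)s1`), keeps everything in compound 3 except for one change: methylamino in place of (methylsulfanyl)methyl on a carbonyl carbon. In words, methylamino stands in place of (methylsulfanyl)methyl on a carbonyl carbon, so that ((methylsulfanyl)methyl)carbonyl becomes methylcarbamoyl.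

The measured steps offer little guidance on this change. Two of them reach compound 3, namely a number no higher from compound 1 to compound 3 (the limit leaves the size open) and a step that the two limits leave unreadable from compound 2 to compound 3, and neither has a readable size. Within the data shown here, neither step alters only the part that changes here, and no measured pair isolates this exchange. With no measured size to build on, the expectation in this assay is for no shift beyond the usual scatter and no firm direction, with generous margins on both sides. The step expected is a step that the limit leaves unreadable from compound 3 to compound 4. This expectation is anchored on compound 3 and its limit of < 100 nM. The estimate for compound 4 is 60 nM, with an expected range from 15 nM to 300 nM.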

Compound 4, half-maximal inhibitory concentration: 22 nM
Compound 4: middle estimate off by 2.7-fold (0.44 log units), on the high side; the range from low to high includes it.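

In this assay compound 4 gives 22 nM, the only exact number among the compounds shown, so methylamino on a carbonyl carbon whose other neighbour is an amide-type nitrogen now has a measured value rather than a limit. Among these compounds, the ((methylcarbamoyl)amino)methyl group of compound 4, set against the group on the same aromatic carbon in compound 1, gives an at least 4.5-fold lower number from compound 1 to compound 4 (0.65 log units; beyond the scatter), the one step with a readable lower bound on its size. Compound 2 and compound 3 carry only limits, and the steps from each of them to compound 4 cannot be read, so the exchange of (methylsulfanyl)methyl for methylamino still has no size and no direction.

As far as these compounds go, whether methylamino gives a lower, higher or equal number than (methylsulfanyl)methyl on this carbonyl carbon remains open, and an exact value for compound 3 would be needed to settle it. From the compounds shown here alone, how a dimethylamino group, an ethylamino group or a longer chain on the same carbonyl carbon would read in this assay also remains open.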